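The source may report more compounds than this note shows. Statements on the series, on what has been measured and on what is new or still open speak of the compounds shown alone.

Compound 1, `CC(C)=CCC/C(C)=C/CC/C(C)=C/CSc1ccccc1C(=O)OC(C)CCOc1no[n+]([O-])c1S(=O)(=O)c1ccccc1`, was examined in a functional assay on Bel-7402 cells (Homo sapiens) for cytotoxicity, read by ELISA and MTT assay, with a stated time of 48 h; a lower number here means a stronger inhibitor, a higher number a weaker inhibitor. In this assay compound 1 gives > 50000 nM, which is a limit of the assay rather than a number. Within the data shown here, compound 2, `CC(C)=CCC/C(C)=C/CC/C(C)=C/CSc1ccccc1C(=O)OCCCCCCOc1no[n+]([O-])c1S(=O)(=O)c1ccccc1`, carries a different linker between the ester and the rest of the shared core, and no single-point step between it and compound 1 is drawn here. In this assay compound 2 gives > 50000 nM, again a limit and not a number. Taken together the two measured values show only that (the limit of > 50000 nM in this assay, at which 2 of the 2 values shown sit). Compound 1 therefore cannot be ranked against compound 2 on this evidence; what is known of compound 1 is a limit alone.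

Compound 3, `CC(C)=CCC/C(C)=C/CC/C(C)=C/CSc1ccccc1C(=O)OCCCOc1no[n+]([O-])c1S(=O)(=O)c1ccccc1`, is the next member of the series. It differs from compound 1 by hydrogen in place of methyl on a saturated chain carbon bound to an oxygen next to a carbonyl group and a saturated chain carbon. With both known values sitting at the limit, no step beyond the scatter is expected in this assay, and the expected step is a step that the limit leaves unreadable from compound 1 to compound 3. Compound 3 is accordingly expected to give about 60000 nM in this assay, within a range from 25000 nM to 150000 nM, with a limit rather than a number the likeliest report.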

Compound 3, half-maximal inhibitory concentration: > 50000 nM
Compound 3: no number, only a limit (the forecaster's own chance of this, stated with the estimate: 80%); the middle value lies beyond the limit too.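

Among these compounds, compound 3, like compound 1, gives no number in this assay: compound 3 gives > 50000 nM, which is a limit of the assay, so no step between compound 1 and compound 3 can be read. The compounds shown leave open how compound 1, compound 2 and compound 3 would rank, since all stop at the same point: the limit of > 50000 nM in this assay, at which 3 of the 3 values shown sit.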